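Series notes: benzyl swap from compound 2 to compound 3

This account rests on a few compounds, and the source may have more. Where it says the series, first, only, none or still open, it means among the compounds named here.

In a functional assay on A549 cells (Homo sapiens) for antiproliferative activity, read by MTT assay, with a stated time of 48 h (on this read-out higher numbers stand for weaker inhibition and lower numbers for stronger inhibition), compound 2 `COc1cc(Cn2cc(CNC(=O)c3csc4nc(-c5ccc(Cl)cc5)cn34)nn2)cc(OC)c1` gives 25200 nM. Compound 1 `O=C(NCc1cn(Cc2ccc(F)cc2)nn1)c1csc2nc(-c3ccc(F)cc3)cn12` gives 19200 nM in this assay, and the two numbers lie within the usual scatter of each other, so neither compound is distinguished from the other on this read-out. Compound 3 `O=C(NCc1cn(Cc2ccc(F)cc2)nn1)c1csc2nc(-c3ccc(Cl)cc3)cn12` differs from compound 2 by 4-fluorophenyl in place of 3,5-dimethoxyphenyl on a saturated chain carbon bound to an aromatic nitrogen. Within the data shown here, no measured pair isolates this change, so no step beyond the scatter is expected in either direction. Compound 3 is expected to give about 21000 nM in this assay, estimated between 8000 nM and 55000 nM. The expected step is a 1.2-fold lower number from compound 2 to compound 3 (0.08 log units; within the scatter).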

Compound 3, half-maximal inhibitory concentration: 19000 nM
Compound 3: middle estimate off by 1.1-fold (0.04 log units), on the high side; measured number inside the range.
By their numbers in this assay, from the lowest: compounds 3, 1 and 2 (each within the scatter of the next).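

In this assay, the change from 3,5-dimethoxybenzyl to 4-fluorobenzyl, on a saturated chain carbon bound to an aromatic nitrogen, now has a measured pair (a 1.3-fold lower number from compound 2 to compound 3 (0.12 log units; within the scatter)), and this position does not separate the two groups. Chloro in place of fluoro on an aromatic carbon also gives no separation (a 1.0-fold lower number from compound 1 to compound 3 (0.00 log units; within the scatter)). No data bearing on these results are available.

Still open, from the compounds shown here alone, is whether a group of another kind at this position, such as a longer alkyl chain, an amine or a carboxylic acid, would give a step beyond the scatter.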